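Swapping chloro for methoxy on a thiophene-linked amidine

The source may hold more compounds than are shown below. What is called first, only, known or untested is meant among the compounds shown, and "the series" means these compounds.

Three compounds with a shared core have been examined in an ADME assay on cells (Erythrocyte, Homo sapiens) for activation, read by hemolysis, with a stated time of 30 min, tested at 2.5 mM; on this read-out higher numbers stand for a stronger effect at the one concentration tested and lower numbers for a weaker effect. Compound 1, `N=C(N)c1ccc(-c2ccc(-c3ccc(Cl)cc3)s2)s1`, gives 14.3% in this assay. Compound 3, `COc1cc(-c2ccc(-c3ccc(C(=N)N)s3)s2)cc(OC)c1OC`, gives 11.3%, a number within the usual scatter of the value for compound 1, so the two cannot be told apart on this read-out. Compound 2, `N=C(N)c1ccc(-c2ccc(-c3cc(Cl)cc(Cl)c3)s2)s1`, is reported in this assay only as "non-toxic" (no number reported), without a number. Compound 1 therefore stands alongside compound 3 at the modest level of hemolysis seen so far, with compound 2 described in words only.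

The next compound, compound 4, `COc1ccc(-c2ccc(-c3ccc(C(=N)N)s3)s2)cc1`, has not yet been measured. It differs from compound 1 in one place: methoxy in place of chloro on an aromatic carbon. The group that leaves and the group that enters both sit on the same aromatic carbon, para to a large group.

Going by the values given here, nothing among the measured compounds shows a step of this exact kind, so the expectation rests on the closeness of compound 1 and compound 3. The change is expected to move the hemolysis little, if at all, with the step of a number 3.3 percentage points lower from compound 1 to compound 4 (within the scatter) estimated to lie within the scatter. Compound 4 is accordingly estimated at 11%, with a range from 3% to 22%.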

Compound 4, a percentage reported as activity, at one concentration (the size of the read-out at that concentration, not a potency): 41%
Beside the measured number, compound 4's estimate is 30 percentage points below it; the measured number lies above the stated range.
By their numbers in this assay, from the lowest: compounds 3 and 1 (each within the scatter of the next); then compound 4.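

In this assay, methoxy in place of chloro on an aromatic carbon, para to a large group, proves not to be a silent exchange: the read-out shows a step of a number 26.7 percentage points higher from compound 1 to compound 4 (beyond the scatter) and so stands clear of the usual scatter. Going by these compounds alone, until now no two measured compounds differed in one place, so this is the first direct sign that hemolysis on the shared core responds to the group held at this position of the six-membered aromatic ring of carbon only. The data shown give no measured property that accounts for the size or direction of this step, so the result remains an observation without an explanation.

A single step at a single position leaves open whether the rise belongs to methoxy itself or would follow other replacements of chloro, such as a hydroxyl, an amine, a carboxylic acid or a longer chain like ethoxy at the same aromatic carbon. It also leaves open whether the same exchange would give a similar step at another carbon of that ring.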